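Dropping the Acyl Group: Expected Loss of Cell Potency

This account rests on a few compounds, and the source may have more. Where it says the series, first, only, none or still open, it means among the compounds named here.

Of the compounds shown here, three have been measured in a functional assay on HCT-15 cells (Homo sapiens) for cytotoxicity, read by sulforhodamine B assay, with a stated time of 72 h; on this read-out higher numbers stand for weaker inhibition of growth and lower numbers for stronger inhibition of growth. Compound 1 `O=C(Nc1cc(C(F)(F)F)cc(C(F)(F)F)c1)C1CCc2ccccc2N1C(=O)c1ccc(Cl)cc1` gives 2220 nM, the lowest of the three numbers; compound 2 `O=C(Nc1ccccc1O)C1CCc2ccccc2N1C(=O)c1ccccc1` gives 3830 nM, within the scatter of compound 1, while compound 3 `O=C(Nc1ccccc1O)C1CCc2ccccc2N1C(=O)c1ccccc1Cl` gives 44900 nM. Within the data shown here, the only single-point step seen, a 12-fold higher number from compound 2 to compound 3 (1.07 log units; beyond the scatter), shows that even one added chloro on the part that compound 4 loses shifts the number strongly. Compound 4 `O=C(Nc1cc(C(F)(F)F)cc(C(F)(F)F)c1)C1CCc2ccccc2N1` carries a deeper change: hydrogen in place of (4-chlorophenyl)carbonyl on a nitrogen on an aromatic ring in a ring. Among the measured compounds shown here, no measured step removes this whole group, so the expectation leans on the size of that one step. The step is expected to be a 6.8-fold higher number from compound 1 to compound 4 (0.83 log units; beyond the scatter). Compound 4 is estimated at 15000 nM, within 3000 nM to 60000 nM.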

Compound 4, concentration for 50% growth inhibition: 8700 nM
Compound 4: the middle estimate sits 1.7-fold (0.24 log units) above what was measured; low and high end bracket the measured number.
By their numbers in this assay, from the lowest: compounds 1 and 2 (each within the scatter of the next); then compound 4; then compound 3.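

Replacing the whole (4-chlorophenyl)carbonyl on the ring nitrogen with hydrogen gives a 3.9-fold higher number from compound 1 to compound 4 (0.59 log units; beyond the scatter) in this assay. The step is beyond the scatter but modest, so growth inhibition is weaker without this group yet remains measurable, and the group is not required for activity on this read-out. Nothing available explains this shift. From the compounds shown here alone, whether a small acetyl or methyl on this nitrogen would restore the number of compound 1 remains open. Also open, going by these compounds, is whether removing the acyl group would have a similar effect on compound 2.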